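The source may hold more compounds than are shown below. What is called first, only, known or untested is meant among the compounds shown, and "the series" means these compounds.

Compound 1 `CC(C)[C@H](NC(=O)c1cc(Cl)ccc1OCCN)C(=O)Nc1ccc([N+](=O)[O-])cc1Cl` gives > 10000 nM as a limit
Compound 2 `CC(C)[C@H](NC(=O)c1cc(Cl)ccc1OCCNC(=O)O)C(=O)Nc1ccc([N+](=O)[O-])cc1Cl` gives > 10000 nM as a limit

In a functional assay on MDA-MB-231 cells (Homo sapiens) for inhibition, read by MTT assay, with a stated time of 72 h (a lower number here means a stronger inhibitor, a higher number a weaker inhibitor), compound 2 gives > 10000 nM and this is a limit of the assay, not a number. Compound 1 gives > 10000 nM and this too is only a limit. The measurements so far therefore come down to the limit of > 10000 nM in this assay, at which 2 of the 2 values shown sit, and no numerical value is available yet.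

Compound 3 `COC(=O)NCCOc1ccc(Cl)cc1C(=O)N[C@H](C(=O)Nc1ccc([N+](=O)[O-])cc1Cl)C(C)C` differs from compound 2 by methyl in place of hydrogen on an oxygen next to a carbonyl group and so has methyl in place of hydrogen on an oxygen next to a carbonyl group, turning carboxy into methoxycarbonyl. Within the data shown here, one measured step bears on this change, since it concerns the same carboxy group. That is a step that the two limits leave unreadable from compound 1 to compound 2 and its size cannot be read. It offers no size or direction to carry over, so no step beyond the scatter is expected in this assay. The estimated step is a step that the limit leaves unreadable from compound 2 to compound 3 and it is a loose expectation. For compound 3 the expected value is 15000 nM with an estimated range of 5000 nM to 40000 nM and the assay may well report only a limit again.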

Compound 3, half-maximal inhibitory concentration: > 10000 nM
Compound 3 gave a limit, no number; the forecaster's own chance of this, stated with the estimate: 80%; the middle value lies beyond the limit too.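

Among these compounds, the values for compound 1, compound 2 and compound 3 are all limits, not numbers, so no step among them can be read in this assay: the limit of > 10000 nM in this assay, at which 3 of the 3 values shown sit.

The compounds shown leave open how large any difference between hydrogen, carboxy and methoxycarbonyl on the amine nitrogen is, and in which direction it runs.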